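Alkyne side-chain variations on a fluorinated oxindole core

A few compounds are considered here, and "the series" means these few. Any claim that something is new, unique, unknown or untested is made for them only; others in the source may bear on it.

Measured compounds in a functional assay on MDA-MB-435 cells (Homo sapiens) for inhibition; on this read-out lower numbers stand for stronger inhibition and higher numbers for weaker inhibition:
Compound 1 `COc1cc[nH]c1/C=C1\C(=O)Nc2ccc(F)c(C#C[C@H](N)CO)c21` gives 320 nM.
Compound 2 `COc1cc[nH]c1/C=C1\C(=O)Nc2ccc(F)c(C#C[C@@H](N)CO)c21` gives 300 nM.
Compound 3 `CN[C@H](C#Cc1c(F)ccc2c1/C(=C/c1[nH]ccc1OC)C(=O)N2)CO` gives 349 nM.

Compound 3 stands highest of the three numbers, yet all three lie within the scatter of one another: the step from compound 1 to compound 2, which rests on configuration alone (the fact that compounds 1 and 2 differ only in the configuration as drawn), is a 1.1-fold lower number from compound 1 to compound 2 (0.03 log units; within the scatter); the step of a 1.1-fold higher number from compound 1 to compound 3 (0.04 log units; within the scatter) and the step of a 1.2-fold higher number from compound 2 to compound 3 (0.07 log units; within the scatter) are likewise within the scatter. Compound 4 `CCN[C@H](C#Cc1c(F)ccc2c1/C(=C/c1[nH]ccc1OC)C(=O)N2)[C@@H](C)O` carries the change (1-(ethylamino)-2-hydroxypropyl in place of 2-hydroxy-1-(methylamino)ethyl on a triple-bonded carbon). For the measured compounds named here, the steps that bear on it, exchange at the amine nitrogen and at the substituent on the triple-bonded carbon, were all small, so no step beyond the scatter is expected in this assay. Compound 4 is estimated at 400 nM, between 150 nM and 1200 nM, a step of a 1.1-fold higher number from compound 3 to compound 4 (0.06 log units; within the scatter) that is expected to stay within the scatter.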

Compound 4, half-maximal inhibitory concentration: 1070 nM
Compound 4: the middle estimate sits 2.7-fold (0.43 log units) below what was measured, and the stated range covers the measured number.
By their numbers in this assay, from the lowest: compounds 2, 1 and 3 (each within the scatter of the next); then compound 4.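

In this assay the side chain on the triple-bonded carbon proves not to be indifferent, with a 3.1-fold higher number from compound 3 to compound 4 (0.49 log units; beyond the scatter) for 1-(ethylamino)-2-hydroxypropyl in place of 2-hydroxy-1-(methylamino)ethyl. Against 1-amino-2-hydroxyethyl the change also lies beyond the scatter, with a 3.6-fold higher number from compound 2 to compound 4 (0.55 log units; beyond the scatter) and a 3.3-fold higher number from compound 1 to compound 4 (0.52 log units; beyond the scatter) in the same direction, whereas the earlier steps all stayed within it. Nothing measured here explains this step.

On these data alone, compound 4 alters the amine substituent and the carbon chain together, so which of them carries the step stays open. As far as these compounds go, how a tertiary amine, a carboxylic acid or a longer chain would read here also stays open.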